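The source may report more compounds than this note shows. Statements on the series, on what has been measured and on what is new or still open speak of the compounds shown alone.

The measured compounds and their numbers in a functional assay on the whole organism (blood) with Rattus norvegicus as the target, with stated times of 24 h and 1 h, at a dose of 5 mg/kg by the intraperitoneal route; a higher number here means a stronger effect of the compound at the dose given, a lower number a weaker effect:
compound 1 `COc1ccc(Cl)cc1C(=O)NCCC1CCN(S(=O)(=O)NC(=O)NC[C@@H]2C[C@@H]3C=C[C@@H]2C3)CC1` gives 37%
compound 2 `COc1ccc(NC(=O)NS(=O)(=O)N2CCC(CCNC(=O)c3cc(Cl)ccc3OC)CC2)cc1` gives 27%
compound 3 `COc1ccc(Cl)cc1C(=O)NCCC1CCN(S(=O)(=O)NC(=O)NN2CCCCCC2)CC1` gives 36%

Compound 1 stands at the top of these three numbers, but neither of the other two is separated from it beyond the scatter: the step of a number 10 percentage points lower from compound 1 to compound 2 (within the scatter) and the step of a number 1 percentage points lower from compound 1 to compound 3 (within the scatter) are both small, and so is the step of a number 9 percentage points higher from compound 2 to compound 3 (within the scatter). All three steps change only the group on the amide-type nitrogen of the shared core.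

Compound 4 `O=C(NC[C@@H]1C[C@@H]2C=C[C@@H]1C2)NS(=O)(=O)N1CCC(CCNC(=O)c2cccc3c2OCCO3)CC1` changes a different part of compound 1: 2,3-dihydro-1,4-benzodioxin-5-yl in place of 5-chloro-2-methoxyphenyl on a carbonyl carbon. Within the data shown here, none of the measured steps touches this carbonyl-attached ring, so no measured step bears directly on the change; the three steps that are known all lie within the scatter, and the numbers across the series spread little. With nothing pointing to a change beyond the scatter, compound 4 is expected to give a number close to that of compound 1, a step of a number 3 percentage points lower from compound 1 to compound 4 (within the scatter).

Compound 4 is therefore estimated at 34%, within a range of 15% to 55%.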

Compound 4, a percentage reported as activity, at one dose (the size of the read-out at that dose, not a potency): 11%
Compound 4: the middle estimate sits 23 percentage points above what was measured; measured number below the stated range.
By their numbers in this assay, from the lowest: compound 4; then compounds 2, 3 and 1 (each within the scatter of the next).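

In this assay, among these compounds, 2,3-dihydro-1,4-benzodioxin-5-yl in place of 5-chloro-2-methoxyphenyl on a carbonyl carbon gives a number 26 percentage points lower from compound 1 to compound 4 (beyond the scatter) and is the only step that lies beyond the scatter. The three changes on the amide-type nitrogen all stayed within the scatter, so among these compounds the group on the carbonyl carbon is the one place where a single change clearly moved the read-out. Nothing available gives a reason for this drop.

The change removes the chlorine and alters the methoxy group in one step, so the compounds shown do not separate the two, and a plain 2-methoxyphenyl group on the carbonyl carbon would bear on this. On these data alone, it also remains open whether the same drop appears with azepan-1-yl or 4-methoxyphenyl on the amide-type nitrogen.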